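Saturated-chain homologation on the ring amine, trachea series

A few compounds are considered here, and "the series" means these few. Any claim that something is new, unique, unknown or untested is made for them only; others in the source may bear on it.

Measured so far:
compound 1, `CCCN1CC[C@@]2(OC)OC(N)=C(C#N)[C@@H](c3ccccc3)[C@@H]2C1`: 20700 nM
compound 2, `CCN1CC[C@@]2(OC)OC(N)=C(C#N)[C@@H](c3ccc(OC)cc3)[C@@H]2C1`: 25500 nM

Both compounds were run in a functional assay on trachea (Cavia porcellus); a higher number here means a weaker inhibitor, a lower number a stronger inhibitor. Compound 1 gives 20700 nM and compound 2 gives 25500 nM. Compound 2 holds the highest of the two numbers, but its nearest neighbour, compound 1, sits only slightly lower, a gap that lies within the scatter, so no order between the two is claimed. Among the compounds with values here, compound 1 and compound 2 differ in more than one place, and no single step is read from them.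

Compound 3, `CCCN1CC[C@@]2(OC)OC(N)=C(C#N)[C@@H](c3ccc(OC)cc3)[C@@H]2C1`, is not yet measured. Relative to compound 2 the change is methyl in place of hydrogen on a saturated chain carbon, two bonds along the chain from an amine nitrogen in a ring. Nothing in the two measured compounds isolates this change, so the expectation rests on the level both share. Within the data shown here, with compound 2 at 25500 nM and compound 1 at 20700 nM, the series so far sits at one weak level.

The step expected from compound 2 to compound 3 is a 1.2-fold lower number from compound 2 to compound 3 (0.08 log units; within the scatter), that is, none beyond the scatter in either direction. Compound 3 is therefore estimated at 21000 nM in this assay, with a range from 8000 nM to 55000 nM.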

Compound 3, half-maximal inhibitory concentration: 21300 nM
Compound 3: the middle estimate sits 1.0-fold (0.01 log units) below what was measured; the range from low to high includes it.
By their numbers in this assay, from the lowest: compounds 1, 3 and 2 (each within the scatter of the next).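

In this assay, methyl in place of hydrogen on a saturated chain carbon, two bonds along the chain from an amine nitrogen in a ring, which is the change from ethyl to propyl, now has a reading of its own: a 1.2-fold lower number from compound 2 to compound 3 (0.08 log units; within the scatter) and so no response beyond the scatter at this position for this one added carbon. Methoxy in place of hydrogen on an aromatic carbon can also be read alone, as a 1.0-fold higher number from compound 1 to compound 3 (0.01 log units; within the scatter) and likewise no response beyond the scatter. Neither single change therefore moves this pair of comparisons off the weak level seen earlier, and no measured information on these compounds bears on the result.

From the compounds shown here alone, whether the same holds for a longer chain such as butyl, or for a benzyl group, on the amine nitrogen in a ring remains open, as does the reading for chloro or hydroxyl in place of the methoxy group. With all three compounds within the scatter of one another, the compounds shown also leave open whether any change on the shared core can produce a step beyond the scatter.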